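The source may hold more compounds than are shown below. What is called first, only, known or untested is meant among the compounds shown, and "the series" means these compounds.

Measured compounds in an ADME assay on cells (Lymphocyte, Homo sapiens) for cytotoxicity, read by MTT assay, with a stated time of 48 h; on this read-out lower numbers stand for stronger inhibition and higher numbers for weaker inhibition:
compound 1, `COC(=O)/C(=C\c1ccc(O)cc1)Sc1ccnc2cc(Cl)ccc12`, 33700 nM
compound 2, `COC(=O)/C(=C\c1ccc(OC(=O)c2ccc(OC)cc2)cc1)Sc1ccnc2cc(Cl)ccc12`, 63500 nM
compound 3, `COC(=O)/C(=C\c1ccc(OC(=O)c2cc(OC)cc(OC)c2)cc1)Sc1ccnc2cc(Cl)ccc12`, 84100 nM

Compound 1 gives the lowest number of the three in this assay; its nearest neighbour is compound 2, a step of a 1.9-fold higher number from compound 1 to compound 2 (0.28 log units; within the scatter), and its furthest is compound 3, a step of a 2.5-fold higher number from compound 1 to compound 3 (0.40 log units; beyond the scatter). Between the two esters the difference is a 1.3-fold higher number from compound 2 to compound 3 (0.12 log units; within the scatter).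

Compound 4, `COC(=O)/C(=C\c1ccc(OC(=O)c2ccc(OC)c(OC)c2)cc1)Sc1ccnc2cc(Cl)ccc12`, is not yet measured. It differs from compound 1 in one place: (3,4-dimethoxyphenyl)carbonyl in place of hydrogen on an oxygen on an aromatic ring. The two measured steps that bear on this change are the ones from compound 1 to compound 2 and from compound 1 to compound 3, both of which replace the same hydrogen with a methoxy-bearing benzoyl group and both of which move the number upward, one within the scatter and one modestly beyond it. Compound 4 carries a (3,4-dimethoxyphenyl)carbonyl group of the same kind, so a comparable upward step is expected, a 2.1-fold higher number from compound 1 to compound 4 (0.32 log units; beyond the scatter). The number for compound 4 in this assay is therefore estimated at 70000 nM, with a range from 40000 nM to 120000 nM.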

Compound 4, half-maximal inhibitory concentration: 51100 nM
Estimate against measurement, compound 4: 1.4-fold (0.14 log units) above; measured number inside the range.
By their numbers in this assay, from the lowest: compounds 1, 4, 2 and 3 (each within the scatter of the next, the first and the last beyond it).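

In this assay, the (3,4-dimethoxyphenyl)carbonyl group on the oxygen on the aromatic ring gives a step that stays inside the scatter (a 1.5-fold higher number from compound 1 to compound 4 (0.18 log units; within the scatter)), so this group, like the 4-methoxyphenyl ester of compound 2, cannot be told apart from the hydrogen of compound 1. Compound 4 also cannot be separated from either of the other esters (a 1.6-fold lower number from compound 3 to compound 4 (0.22 log units; within the scatter); a 1.2-fold lower number from compound 2 to compound 4 (0.09 log units; within the scatter)), so the added methoxy and the changed methoxy pattern on the benzoyl ring make no readable difference, and compound 3 alone stands beyond the scatter from compound 1. Nothing available bears on why these esters behave alike.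

The compounds shown leave open whether a benzoyl ring carrying an amine or a carboxylic acid in place of methoxy would move the number beyond the scatter. They also leave open what a small acetyl group on the same oxygen would do.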